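The source may report more compounds than this note shows. Statements on the series, on what has been measured and on what is new or still open speak of the compounds shown alone.

Of the compounds shown here, three have been measured so far in a functional assay on MDA-MB-436 cells (Homo sapiens) for antiproliferative activity, read by MTT assay, with a stated time of 48 h; on this read-out lower numbers stand for stronger inhibition and higher numbers for weaker inhibition. Compound 1 `C=CS(=O)(=O)N1CCN(c2ncnc3sc(-c4ccccc4)cc23)CC1` gives 21100 nM, and compound 2 `C=CS(=O)(=O)N1CCN(c2ncnc3ccc(-c4ccccc4)cc23)CC1` gives 23400 nM. Compound 3 `CN1CCN(c2ccc(-c3cc4c(N5CCN(S(=O)(=O)/C=C/c6ccccc6)CC5)ncnc4s3)cc2)CC1` gives 8670 nM, the lowest of the three numbers, and its gaps to compound 1 and to compound 2 both lie beyond the usual scatter, so compound 3 counts as the strongest inhibitor here. Compound 4 `CN1CCN(c2ccc(-c3cc4c(N5CCN(C(=O)Nc6ccccc6F)CC5)ncnc4s3)cc2)CC1` has not yet been measured; it differs from compound 3 in one place: (2-fluorophenyl)carbamoyl in place of (2-phenylethenyl)sulfonyl on an amine nitrogen in a ring. Going by the values given here, no measured pair shows a change of this kind, so the step is expected to be modest. The step from compound 3 to compound 4 is estimated at a 1.7-fold higher number from compound 3 to compound 4 (0.24 log units; within the scatter), toward a somewhat higher number. In this assay compound 4 is therefore expected to give about 15000 nM, with a plausible range from 5000 nM to 45000 nM.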

Compound 4, half-maximal inhibitory concentration: 14300 nM
Estimate against measurement, compound 4: 1.0-fold (0.02 log units) above, within the range that was stated.
By their numbers in this assay, from the lowest: compounds 3, 4, 1 and 2 (each within the scatter of the next, the first and the last beyond it).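

In this assay, placing (2-fluorophenyl)carbamoyl in place of (2-phenylethenyl)sulfonyl on the ring amine nitrogen gives a 1.6-fold higher number from compound 3 to compound 4 (0.22 log units; within the scatter) and so no change that can be told from the scatter. At this position, then, a group with one hydrogen-bond donor and a group with none read alike, even though the link to the aromatic ring differs. Nothing at hand explains this result. The compounds shown leave open whether the fluorine matters, as phenylcarbamoyl without it would show, and how a small acetyl group on the same nitrogen would compare.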